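Shifting the Fluorine in Compound 2

The source may report more compounds than this note shows. Statements on the series, on what has been measured and on what is new or still open speak of the compounds shown alone.

In a functional assay on A-375 cells (Homo sapiens) for antiproliferative activity (on this read-out lower numbers stand for stronger inhibition and higher numbers for weaker inhibition), compound 1 `O=C(Nc1ccc(-c2cscn2)cc1)C1CCCN(C(=O)c2ccc(F)c(F)c2)C1` reaches only a limit, > 20000 nM.

Going by the values given here, compound 2 `O=C(Nc1ccc(-c2cscn2)cc1)C1CCCN(Cc2ccccc2F)C1` gives 4000 nM, the only actual number so far. Compound 3 `O=C(Nc1ccc(-c2cscn2)cc1)C1CCCN(Cc2cccc(F)c2)C1` differs from it by 3-fluorophenyl in place of 2-fluorophenyl on a saturated chain carbon bound to an amine nitrogen in a ring. Among the compounds with values here, the one measured step, an at least 5.0-fold lower number from compound 1 to compound 2 (0.69 log units; beyond the scatter), exchanged a carbonyl-linked group for 2-fluorobenzyl, so it offers little guide to this smaller change. The expected result is no change at the digits printed from compound 2 to compound 3 (within the scatter), with no shift beyond the scatter. For compound 3, the estimate is 4000 nM, within an expected range of 1500 nM to 11000 nM.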

Compound 3, half-maximal inhibitory concentration: 2450 nM
Compound 3: middle estimate off by 1.6-fold (0.21 log units), on the high side; the measured number falls inside the stated range.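

Exchanging 2-fluorophenyl for 3-fluorophenyl gives a 1.6-fold lower number from compound 2 to compound 3 (0.21 log units; within the scatter), so the two fluorine placements cannot be told apart in this assay. With 3-fluorobenzyl in place of (3,4-difluorophenyl)carbonyl, the result is an at least 8.1-fold lower number from compound 1 to compound 3 (0.91 log units; beyond the scatter), showing that a second fluorobenzyl group also reads clearly better than the carbonyl-linked group. The true size of that step is unknown, because the value for compound 1 is a limit and not a number: the limit of > 20000 nM in this assay, at which 1 of the 3 values shown sits.

Still open, from the compounds shown here alone, is how the result would read with a nitrile in place of the fluorine on the phenyl ring, or with a longer chain linking that ring to the amine nitrogen.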